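This account rests on a few compounds, and the source may have more. Where it says the series, first, only, none or still open, it means among the compounds named here.

The shared core of compound 1, `COC(=O)C1=C(C)NC(=O)NC1c1ccc(OC)cc1`, carries a methoxy group on its aromatic ring, and in an assay for inhibition of beta-glucuronidase (Bos taurus), read by spectrophotometry, with a stated time of 30 min (a lower number here means a stronger inhibitor, a higher number a weaker inhibitor), compound 1 gives 59200 nM. Among the measured compounds shown here, compound 2, `COC(=O)C1=C(C)NC(=O)NC1c1ccc(Br)cc1`, carries bromo instead, and in this assay compound 2 gives 64100 nM; its only neighbour is compound 1, since a 1.1-fold higher number from compound 1 to compound 2 (0.03 log units; within the scatter). Compound 3, `COC(=O)C1=C(C)NC(=O)NC1c1ccc(C(C)C)cc1`, differs from compound 2 by isopropyl in place of bromo on an aromatic carbon. For the measured compounds named here, no measured step swaps bromo for isopropyl, and the one step on this aromatic carbon stayed within the scatter, so compound 3 is expected to give 62000 nM (range 25000 nM to 150000 nM), which would mean a 1.0-fold lower number from compound 2 to compound 3 (0.01 log units; within the scatter).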

Compound 3, half-maximal inhibitory concentration: "not active" (no number reported)
For compound 3 the study gives words and no number, and the estimate cannot be compared.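

Among the compounds shown here, compound 3 is reported only in words, as "not active", so no step from compound 2 to compound 3 can be read. No other data bear on this result. In this assay the compounds shown leave open how isopropyl compares numerically with bromo or methoxy.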